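The source may report more compounds than this note shows. Statements on the series, on what has been measured and on what is new or still open speak of the compounds shown alone.

Compound 1 `CCCCSc1nc(N)nc2c1ncn2/C=C1/CC1(CO)CO` and compound 2 `CCCCCOc1nc(N)nc2c1ncn2/C=C1/CC1(CO)CO` share one core and differ only in the group on one aromatic carbon. In an ADME assay on HFF cells (Homo sapiens) for cytotoxicity, with a stated time of 8 days (a higher number here means that more compound is tolerated, a lower number that less compound is tolerated), compound 1 reaches only a limit of the assay, > 300000 nM. In this assay compound 2 gives 259000 nM. Within the data shown here, the single measured step, an at least 1.1-fold lower number from compound 1 to compound 2 (0.06 log units; that floor lies within the scatter), cannot be sized beyond its floor because of the limit of > 300000 nM in this assay, at which 1 of the 2 values shown sits. Compound 3 `Nc1nc(OCc2ccccc2)c2ncn(/C=C3/CC3(CO)CO)c2n1` differs from compound 1 by benzyloxy in place of butylsulfanyl on an aromatic carbon, so a benzyloxy now takes the position of the butylsulfanyl on an aromatic carbon. The step from compound 1 to compound 2 is the one that bears on this change, since it also replaced the butylsulfanyl at that aromatic carbon, and its floor lies within the scatter. Compound 3 is therefore expected to show an at least 1.2-fold lower number from compound 1 to compound 3 (0.07 log units; that floor lies within the scatter) in this assay, that is, no shift beyond the scatter. The half-maximal cytotoxic concentration of compound 3 is estimated at 250000 nM, with a range from 100000 nM to 400000 nM.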

Compound 3, half-maximal cytotoxic concentration: > 300000 nM
Compound 3: a limit, no number; the forecaster's own chance of this, stated with the estimate: 45%; middle value at least 1.2-fold (0.07 log units) away from the limit.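

In this assay compound 3 gives > 300000 nM, which is a limit of the assay and not a number. Among these compounds, the new information is that this aromatic carbon, so far seen only with the open chains butylsulfanyl and pentyloxy, also carries benzyloxy, with its six-membered aromatic ring of carbon only, without any shift that can be told from the scatter: the one readable step is an at least 1.1-fold higher number from compound 2 to compound 3 (0.06 log units; that floor lies within the scatter). The step between compound 1 and compound 3 cannot be read, and the readable step cannot be sized beyond its floor, because the series runs into the ceiling of the assay: the limit of > 300000 nM in this assay, at which 2 of the 3 values shown sit.

The compounds shown leave open whether any group on this aromatic carbon brings a number clearly lower than those seen here, and how large the true differences among the three compounds are. An amine or a carboxylic acid in that place, or a longer chain on the oxygen, would test how far this tolerance extends.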